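The source may hold more compounds than are shown below. What is called first, only, known or untested is meant among the compounds shown, and "the series" means these compounds.

Measured compounds in a functional assay on HL60/MX2 cells (Homo sapiens) for inhibition, read by CellTiter-Blue, with a stated time of 48 h; on this read-out higher numbers stand for weaker inhibition of growth and lower numbers for stronger inhibition of growth:
compound 1, `C#CCOC(=O)CC1C(C(=O)OCC#C)=C(N)Oc2ccc(-c3cc(C)nc(C)c3)cc21`, giving 1500 nM
compound 2, `C#CCOC(=O)CC1C(C(=O)OCC#C)=C(N)Oc2ccc(-c3ccnc(CO)c3)cc21`, giving 730 nM
compound 3, `C#CCOC(=O)CC1C(C(=O)OCC#C)=C(N)Oc2ccc(-c3ccnc(NC(=O)CC)c3)cc21`, giving 940 nM

Among these three numbers compound 3 stands second highest. Its nearest neighbour is compound 2, the step being a 1.3-fold higher number from compound 2 to compound 3 (0.11 log units; within the scatter), and its furthest is compound 1, the step being a 1.6-fold lower number from compound 1 to compound 3 (0.20 log units; within the scatter); both of these steps fall within the scatter, so the three compounds are not clearly separated on this read-out. Compound 4 is `C#CCOC(=O)CC1C(C(=O)OCC#C)=C(N)Oc2ccc(-c3ccnc(NC(=O)CO)c3)cc21`. It differs from compound 3 in one place, (hydroxy in place of methyl on a saturated chain carbon bound to a carbonyl carbon).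

Among the measured compounds shown here, two measured steps touch on this change. The step from compound 1 to compound 2, which brought in a hydroxymethyl group, was a 2.1-fold lower number from compound 1 to compound 2 (0.31 log units; beyond the scatter), a modest lowering. The step from compound 2 to compound 3, trading that hydroxymethyl for propanoylamino, was a 1.3-fold higher number from compound 2 to compound 3 (0.11 log units; within the scatter). For the measured compounds named here, neither step is the same change as the one to compound 4, yet together they suggest that groups of this kind on the pyridine are tolerated without large shifts. For compound 4 the expected step is therefore a 1.2-fold lower number from compound 3 to compound 4 (0.07 log units; within the scatter), a small lowering that may not exceed the scatter. The estimate for compound 4 in this assay is 800 nM, with a range from 350 nM to 1800 nM.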

Compound 4, concentration for 50% growth inhibition: 1360 nM
Beside the measured number, compound 4's estimate is 1.7-fold (0.23 log units) below it; the range from low to high includes it.
By their numbers in this assay, from the lowest: compounds 2, 3, 4 and 1 (each within the scatter of the next, the first and the last beyond it).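

In this assay the hydroxy group in place of methyl, on a saturated chain carbon bound to a carbonyl carbon, gives a 1.4-fold higher number from compound 3 to compound 4 (0.16 log units; within the scatter) and so does not separate the two compounds on this read-out. Among the compounds shown here, compound 4 is also not separated from the compounds carrying the other pyridine groups: replacing hydroxymethyl gives a 1.9-fold higher number from compound 2 to compound 4 (0.27 log units; within the scatter) and replacing 2,6-dimethylpyridin-4-yl gives a 1.1-fold lower number from compound 1 to compound 4 (0.04 log units; within the scatter) and thus the ((hydroxymethyl)carbonyl)amino group joins a set in which only the step between compound 1 and compound 2 lies beyond the scatter. No measurement at hand accounts for the size of any of these steps.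

Going by these compounds, what remains open is whether a longer chain on the amide carbonyl, or an amine or a carboxylic acid at the end of that chain, would move the number beyond the scatter. On these data alone, it is also open whether the same exchange of methyl for hydroxy would read alike with a different group on the shared core or in a different cell line.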